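This account rests on a few compounds, and the source may have more. Where it says the series, first, only, none or still open, it means among the compounds named here.

Compound 1 `CCNC(=O)c1cc(N)c(Nc2ccc(C#N)cc2)cc1Oc1c(C)cc(CCC#N)cc1C` gives 69.4 ug/mL in a physicochemical assay for solubility, read by HPLC, with a stated time of 4 h, at pH 2, tested at 10 mg/mL; on this read-out higher numbers stand for higher solubility and lower numbers for lower solubility.
Compound 2 `Cc1cc(CCC#N)cc(C)c1Oc1cc(Nc2ccc(C#N)cc2)c(N)cc1C(=O)NC1CC1` gives 141 ug/mL in this assay.
Compound 3 `COC(=O)c1cc(N)c(Nc2ccc(C#N)cc2)cc1Oc1c(Br)cc(CCC#N)cc1OC` gives 1.73 ug/mL in this assay.

Compound 3 stands lowest of the three in this assay, far under compound 1 and compound 2, which both carry a carbamoyl group on the shared core. Compound 4 `CNC(=O)c1cc(N)c(Nc2ccc(C#N)cc2)cc1Oc1c(Br)cc(CCC#N)cc1OC` differs from compound 3 by methylamino in place of methoxy on a carbonyl carbon. For the measured compounds named here, no measured pair makes the change from methoxycarbonyl to methylcarbamoyl; the only measured step, a 2.0-fold higher number from compound 1 to compound 2 (0.31 log units; beyond the scatter), alters just the group on the amide nitrogen and bears on it only indirectly. The higher numbers of compound 1 and compound 2 suggest an upward step, though the two ring substituents of compound 3 are retained. For compound 4 the expected step is a 4.6-fold higher number from compound 3 to compound 4 (0.67 log units; beyond the scatter), giving an estimated 8 ug/mL with a range from 2 ug/mL to 35 ug/mL.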

Compound 4, solubility: 25.8 ug/mL
For compound 4 the middle estimate is 3.2-fold (0.51 log units) below the measured one; the range from low to high includes it.
By their numbers in this assay, from the lowest: compound 3; then compound 4; then compound 1; then compound 2.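

In this assay, methylamino in place of methoxy on a carbonyl carbon gives a 15-fold higher number from compound 3 to compound 4 (1.17 log units; beyond the scatter) as a large step. For the compounds shown here, this is the first direct reading of methoxycarbonyl to methylcarbamoyl, and it shows that this single exchange is enough to produce a large change at this position, whereas the earlier compounds showed only a change of the group on the amide nitrogen.

Going by these compounds, how a carboxylic acid or a dimethylamino group on the same carbonyl carbon would read remains open. No measured evidence on the compounds shown accounts for the size of this step.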